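A few compounds are considered here, and "the series" means these few. Any claim that something is new, unique, unknown or untested is made for them only; others in the source may bear on it.

Compound 1, `Oc1cccc(Nc2nc(NCc3ccccc3)c3ccccc3n2)c1`: 22600 nM. Compound 2, `CN(C)CCNc1nc(-c2ccc(C(C)(C)C)cc2)nc2ccccc12`: > 50000 nM.

Going by the values given here, in a functional assay on DU-145 cells (Homo sapiens) for antiproliferative activity, read by MTT assay (a lower number here means a stronger inhibitor, a higher number a weaker inhibitor), compound 1 gives 22600 nM, the only full number among the two results. Compound 2 is reported only as a limit of the assay, > 50000 nM, and (the limit of > 50000 nM in this assay, at which 1 of the 2 values shown sits). Compound 3, `Fc1ccc(Nc2nc(NCc3ccccc3)c3ccccc3n2)cc1`, has not yet been measured in this assay; it differs from compound 1 by 4-fluorophenyl in place of 3-hydroxyphenyl on a nitrogen on an aromatic ring. Among the compounds with values here, no measured step shows how such a change behaves here. The step of a 1.3-fold higher number from compound 1 to compound 3 (0.12 log units; within the scatter) is expected to be small, within the scatter or leaning slightly toward weaker inhibition. Compound 3 is estimated at 30000 nM, within 10000 nM to 100000 nM.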

Compound 3, half-maximal inhibitory concentration: 23400 nM
Compound 3: the middle estimate sits 1.3-fold (0.11 log units) above what was measured, within the range that was stated.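

Placing 4-fluorophenyl in place of 3-hydroxyphenyl on a nitrogen on an aromatic ring gives a 1.0-fold higher number from compound 1 to compound 3 (0.02 log units; within the scatter) in this assay, the first measured step at this position. The entering group counts no hydrogen-bond donor or acceptor where the leaving group counts one of each, yet the two compounds read alike. Nothing measured here accounts for this result.

Still open, from the compounds shown here alone, is whether an amine or a carboxylic acid on this ring would give a step beyond the scatter. A longer chain in place of the ring is equally untested among the compounds shown.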